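The source may report more compounds than this note shows. Statements on the series, on what has been measured and on what is new or still open speak of the compounds shown alone.

Compound 1, `COc1ccc(/C(=C(/CCNC(=O)NCc2ccccc2)c2ccccc2)c2ccccc2)cc1`, in a functional assay on MCF7 cells (Homo sapiens) for cytotoxicity, read by MTT assay, with a stated time of 72 h (on this read-out lower numbers stand for stronger inhibition and higher numbers for weaker inhibition), gives only a limit, > 50000 nM.
Compound 2, `COc1ccc(/C(=C(/CCNC(=O)NC2CCCCC2)c2ccccc2)c2ccccc2)cc1`, in this assay gives 37200 nM.
Compound 3, `COc1ccc(/C(=C(/CCNC(=O)C(=O)NCc2ccccc2)c2ccccc2)c2ccccc2)cc1`, in this assay gives only a limit, > 50000 nM.

Two of the three measured values sit at the limit of > 50000 nM in this assay, at which 2 of the 3 values shown sit, so most of what is seen here is a floor rather than a number.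

Compound 1 and compound 2 differ by one change, (cyclohexyl in place of benzyl on an amide-type nitrogen). The measured step is an at least 1.3-fold lower number from compound 1 to compound 2 (0.12 log units; that floor lies within the scatter), and its floor is within the scatter, so no real movement can be read from it.

The cores of compound 1 and compound 3 differ by benzylcarbamoyl in place of benzylamino on a carbonyl carbon. On the core of compound 3, the same change gives compound 4, `COc1ccc(/C(=C(/CCNC(=O)C(=O)NC2CCCCC2)c2ccccc2)c2ccccc2)cc1`, through (cyclohexyl in place of benzyl on an amide-type nitrogen). The place is described in the same words in both pairs, so this is the same change made on a different core.

The step from compound 3 to compound 4 is expected to be an at least 1.1-fold lower number from compound 3 to compound 4 (0.04 log units; that floor lies within the scatter), resting on the small step of an at least 1.3-fold lower number from compound 1 to compound 2 (0.12 log units; that floor lies within the scatter). The expectation also rests on the starting point, since compound 3 gives only a limit, > 50000 nM. Compound 4 is estimated at 45000 nM in this assay.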

Compound 4, half-maximal inhibitory concentration: 12100 nM
Beside the measured number, compound 4's estimate is 3.7-fold (0.57 log units) above it, outside the stated range (below it).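

In this assay, cyclohexyl in place of benzyl on the amide-type nitrogen gives an at least 4.1-fold lower number from compound 3 to compound 4 (0.61 log units; beyond the scatter), and the two other steps that reach compound 4 are a 3.1-fold lower number from compound 2 to compound 4 (0.49 log units; beyond the scatter) and an at least 4.1-fold lower number from compound 1 to compound 4 (0.61 log units; beyond the scatter). Compound 3 gives > 50000 nM, which is a limit and not a number, so the step that starts from it has a floor and no exact size. The change is readable on the core of compound 3 but not on the core of compound 1, so this series neither shows nor rules out that its size carries from one core to the other: the same change on two cores in this assay, an at least 1.3-fold lower number (0.12 log units; that floor lies within the scatter) from compound 1 to compound 2 and an at least 4.1-fold lower number (0.61 log units; beyond the scatter) from compound 3 to compound 4; the limit leaves it open whether they differ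

The compounds shown leave open how other groups on that nitrogen would behave, such as a plain phenyl ring, a longer chain like hexyl, or a chain ending in an amine. Much of the set also gives no exact number, which limits any comparison among these compounds: the limit of > 50000 nM in this assay, at which 2 of the 4 values shown sit.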